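From amino to hydroxy on a shared core

The compounds below may be only part of what the source reports. "The series", "measured", "known", "first", "only" and "open" are said of these compounds alone.

Compound 1 `COc1ccc(-n2ccc3c(OC)c(OC)c(OC)cc32)cc1`: 145 nM
Compound 2 `COc1ccc(-n2ccc3c(OC)c(OC)c(OC)cc32)cc1N`: 1540 nM

In a functional assay on MKN-45 cells (Homo sapiens) for antiproliferative activity, with a stated time of 72 h (on this read-out higher numbers stand for weaker inhibition and lower numbers for stronger inhibition), compound 2 holds the higher of the two numbers at 1540 nM, which makes it the weaker inhibitor of the pair. Compound 3 `COc1ccc(-n2ccc3c(OC)c(OC)c(OC)cc32)cc1O` changes one group of compound 2: hydroxy in place of amino on an aromatic carbon. Among the measured compounds shown here, only one measured step touches this carbon, an 11-fold higher number from compound 1 to compound 2 (1.03 log units; beyond the scatter), a large rise seen when amino replaced hydrogen. For the measured compounds named here, no measured compound yet carries hydroxy, so that step is only a loose guide. Hydroxy may not carry the whole of that rise, so a moderate move toward a lower number is expected, though with wide uncertainty. The expected change is a 3.4-fold lower number from compound 2 to compound 3 (0.53 log units; beyond the scatter). For compound 3 the estimated value is 450 nM, within an expected range of 90 nM to 1800 nM.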

Compound 3, half-maximal inhibitory concentration: 5900 nM
Estimate against measurement, compound 3: 13-fold (1.12 log units) below; the measured number lies above the stated range.
By their numbers in this assay, from the lowest: compound 1; then compound 2; then compound 3.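

In this assay, putting hydroxy in place of amino on this aromatic carbon does not recover the activity lost when amino was placed there; instead the number climbs further, with a 3.8-fold higher number from compound 2 to compound 3 (0.58 log units; beyond the scatter). Set against plain hydrogen at the same carbon, hydroxy costs much more, with a 41-fold higher number from compound 1 to compound 3 (1.61 log units; beyond the scatter), so hydrogen gives the strongest inhibition of the three groups and hydroxy the weakest. Amino and hydroxy count the same hydrogen-bond donors and acceptors, yet they differ beyond the scatter, and nothing measured here explains that difference.

Going by these compounds, whether fluoro, methyl or a longer ether such as ethoxy on this carbon would bring the number back toward that of compound 1 stays open. Also open, on these data alone, is whether the same order of hydrogen, amino and hydroxy would hold on another carbon of this ring.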